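Fluoro for bromo at the cytotoxicity limit

A few compounds are considered here, and "the series" means these few. Any claim that something is new, unique, unknown or untested is made for them only; others in the source may bear on it.

In an ADME assay on MT4 cells (Homo sapiens) for cytotoxicity, read by MTT assay (on this read-out lower numbers stand for higher toxicity in this test and higher numbers for lower toxicity in this test), compound 1 (`O=C(CSc1nccn1-c1ccc(Cl)cc1)Nc1ccccc1Br`) gives > 300000 nM as a limit and not a number. Compound 2 (`COc1ccc(-n2ccnc2SCC(=O)Nc2ccccc2Br)cc1`) gives > 298000 nM and this too is only a limit. Compound 3 (`COc1ccc(-n2ccnc2SCC(=O)Nc2ccccc2F)cc1`) follows from compound 2 by fluoro in place of bromo on an aromatic carbon with fluoro in place of bromo on an aromatic carbon. Among the measured compounds shown here, with a step that the two limits leave unreadable from compound 1 to compound 2 as the only measured step, no size carries over, and no step beyond the scatter is expected in this assay for this change. The estimated move is a step that the limit leaves unreadable from compound 2 to compound 3 and no more. Compound 3 is estimated at 300000 nM with an expected range of 120000 nM to 400000 nM on this read-out.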

Compound 3, half-maximal cytotoxic concentration: >= 41900 nM
Compound 3 gave a limit, no number; the forecaster's own chance of this, stated with the estimate: 75%; the middle value is on the limit's open side.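

The step from compound 2 to compound 3 cannot be read in this assay: both results are limits, not numbers. The compounds shown leave open whether fluoro in place of bromo changes the half-maximal cytotoxic concentration at all.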